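The compounds below may be only part of what the source reports. "The series", "measured", "known", "first", "only" and "open" are said of these compounds alone.

Measured so far in a functional assay on MCF7 cells (Homo sapiens) for antiproliferative activity, with a stated time of 5 days; on this read-out higher numbers stand for weaker inhibition and lower numbers for stronger inhibition:
compound 1 `CCCCc1ccc2[nH]c(-c3ccc(OC)cc3)c(/C=N/NC(=O)c3ccc(OC)cc3)c2c1` gives 226 nM
compound 2 `CCCCc1ccc2[nH]c(-c3ccc(OC)cc3)c(/C=N/NC(=O)c3ccccc3OC)c2c1` gives 71 nM
compound 3 `CCCCc1ccc2[nH]c(-c3ccc(OC)cc3)c(/C=N/NC(=O)c3cccnc3)c2c1` gives 75 nM

Compound 3 stands level with compound 2, as the gap is only a 1.1-fold higher number from compound 2 to compound 3 (0.02 log units; within the scatter) and no order can be read between them. Both stand clearly under compound 1, and for compound 3 this is a 3.0-fold lower number from compound 1 to compound 3 (0.48 log units; beyond the scatter) in this set.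

Compound 4 `CCCCc1ccc2[nH]c(-c3ccc(OC)cc3)c(/C=N/NC(=O)c3ccccn3)c2c1` carries pyridin-2-yl in place of pyridin-3-yl on a carbonyl carbon, and the difference reads pyridin-2-yl in place of pyridin-3-yl on a carbonyl carbon with the same atoms joined differently.

Going by the values given here, no measured step swaps one pyridinyl group for another, so the evidence is indirect. The closest parallel is 2-methoxyphenyl in place of 4-methoxyphenyl, also a change with the same atoms joined differently, which gave a 3.2-fold lower number from compound 1 to compound 2 (0.50 log units; beyond the scatter) and shows that such a change can matter here. Against that, exchanging quite different groups gave a 1.1-fold higher number from compound 2 to compound 3 (0.02 log units; within the scatter) at this same place.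

The expected change is therefore small, and a 1.2-fold higher number from compound 3 to compound 4 (0.08 log units; within the scatter) is the estimated step, with no firm direction and no expected departure beyond the scatter. For compound 4 the estimated value is 90 nM in this assay and the expected range runs from 35 nM to 230 nM as a plausible span.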

Compound 4, half-maximal inhibitory concentration: 160 nM
Compound 4: middle estimate off by 1.8-fold (0.25 log units), on the low side; the range from low to high includes it.
By their numbers in this assay, from the lowest: compounds 2 and 3 (each within the scatter of the next); then compounds 4 and 1 (each within the scatter of the next).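

In this assay, going by these compounds alone, the exchange of pyridin-3-yl for pyridin-2-yl on the carbonyl carbon gives a 2.1-fold higher number from compound 3 to compound 4 (0.33 log units; beyond the scatter), so the two pyridinyl groups, with the same atoms joined differently, are not interchangeable at this place, which the earlier compounds could not show. The pyridin-2-yl group also parts from the 2-methoxyphenyl group, with a 2.3-fold higher number from compound 2 to compound 4 (0.35 log units; beyond the scatter), but cannot be told apart from the 4-methoxyphenyl group, with a 1.4-fold lower number from compound 1 to compound 4 (0.15 log units; within the scatter), so the four compounds fall into two levels: compounds 2 and 3 at the lower numbers, compounds 1 and 4 at the higher, with each pair of same-atom groups split across them. No measurement shown here accounts for this split between the pyridinyl groups.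

Left open is how pyridin-4-yl or 3-methoxyphenyl would stand on this carbonyl carbon, and whether a saturated amine such as piperidin-1-yl would fit either level. Also open, as far as these compounds go, is whether the same two levels would hold if the butyl chain on the shared core gave way to a shorter chain or a carboxylic acid.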